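Cyclohexyl amide step on the fluoro core

This account rests on a few compounds, and the source may have more. Where it says the series, first, only, none or still open, it means among the compounds named here.

Of the compounds shown here, three have been measured so far. Compound 1 `C=CC1=C(C(=O)NC2CCCCC2)C(c2ccc(OC)cc2)OC1` carries a cyclohexyl on the amide nitrogen and a methoxy on the aryl ring; in a functional assay on HeLa cells (Homo sapiens) for cytotoxicity, read by MTT assay, with a stated time of 24 h (on this read-out higher numbers stand for weaker inhibition and lower numbers for stronger inhibition), compound 1 gives 24800 nM. Compound 3 `C=CC1=C(C(=O)NCCCCC)C(c2ccc(OC)cc2)OC1` is its pentyl amide; in this assay compound 3 gives only a limit, > 100000 nM. Compound 2 `C=CC1=C(C(=O)NCCCCC)C(c2ccc(F)cc2)OC1` is the pentyl amide on the fluoro core; in this assay compound 2 likewise gives only a limit, > 100000 nM. Both limits are the same one, (the limit of > 100000 nM in this assay, at which 2 of the 3 values shown sit).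

The change cyclohexyl in place of pentyl on an amide-type nitrogen produced an at least 4.0-fold lower number from compound 3 to compound 1 (0.60 log units; beyond the scatter). The two cores differ by fluoro in place of methoxy on an aromatic carbon; the step that the two limits leave unreadable from compound 2 to compound 3 cannot be sized, as both values are limits.

Compound 4 `C=CC1=C(C(=O)NC2CCCCC2)C(c2ccc(F)cc2)OC1` is not yet measured. Relative to compound 2 it carries the change (cyclohexyl in place of pentyl on an amide-type nitrogen), the same change as from compound 3 to compound 1, made at the same place. By analogy with compound 1 the expected step is an at least 2.5-fold lower number from compound 2 to compound 4 (0.39 log units; beyond the scatter), resting on an at least 4.0-fold lower number from compound 3 to compound 1 (0.60 log units; beyond the scatter) alone, since the fluoro core itself has given no readable number. Compound 4 is therefore expected to give about 40000 nM, with 15000 nM to 150000 nM as the expected range.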

Compound 4, half-maximal inhibitory concentration: > 100000 nM
Compound 4: only a limit was reported; the forecaster's own chance of this, stated with the estimate: 30%; middle value at least 2.5-fold (0.39 log units) away from the limit.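

In this assay compound 4 gives only a limit, > 100000 nM. The steps with a limit at both ends cannot be read, so the change to cyclohexyl on the amide nitrogen is neither shown to carry over to the fluoro core nor shown to fail there, and only this much can be stated: the limit of > 100000 nM in this assay, at which 3 of the 4 values shown sit.

Among the compounds shown here, the one readable new step, fluoro in place of methoxy with the cyclohexyl amide held fixed, is an at least 4.0-fold higher number from compound 1 to compound 4 (0.60 log units; beyond the scatter), which shows that the readable cytotoxicity among the cyclohexyl amides belongs to the methoxy core, although it does not show whether the same holds for the pentyl amides.

The compounds shown leave open how far the true values of the limit compounds lie from one another, and so whether the two cores respond differently to the amide change at all. Also open, going by these compounds, is whether a chloro or hydroxy group on the aryl ring, or a benzyl or octyl group on the amide nitrogen, would give a readable number.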